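A few compounds are considered here, and "the series" means these few. Any claim that something is new, unique, unknown or untested is made for them only; others in the source may bear on it.

Measured so far:
compound 1 `COc1ccc2cc(C(C)c3nnc4n3N=C(c3ccc(Br)cc3)CS4)ccc2c1`: 9300 nM
compound 2 `COc1ccc(C2=Nn3c(nnc3C(C)c3ccc(-c4ccccc4)c(F)c3)SC2)cc1`: 4300 nM

In a functional assay on Huh-7 cells (Homo sapiens) for inhibition, read by sulforhodamine B assay, with a stated time of 72 h (on this read-out higher numbers stand for weaker inhibition and lower numbers for stronger inhibition), compound 1 stands at the highest of the two numbers; the nearest is compound 2, whose number in this assay is lower by a gap beyond the usual scatter. Compound 3 `COc1ccc2cc(C(C)c3nnc4n3N=C(c3ccc(C)cc3)CS4)ccc2c1` is not yet measured. It differs from compound 1 in one place: methyl in place of bromo on an aromatic carbon — methyl enters where bromo leaves, on an aromatic carbon of a six-membered aromatic ring of carbon only, para to a large group; cut one bond further out, 4-bromophenyl becomes 4-methylphenyl. Among the measured compounds shown here, no measured pair shows this exchange, so its effect cannot be read from the numbers at hand. In this assay the expected step is small, most likely none beyond the scatter, with a slight lean toward a higher number: a 1.3-fold higher number from compound 1 to compound 3 (0.11 log units; within the scatter). Compound 3 is therefore estimated at 12000 nM, with a range of 4500 nM to 32000 nM.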

Compound 3, half-maximal inhibitory concentration: 8200 nM
For compound 3 the middle estimate is 1.5-fold (0.17 log units) above the measured one, within the range that was stated.
By their numbers in this assay, from the lowest: compounds 2, 3 and 1 (each within the scatter of the next, the first and the last beyond it).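

In this assay, among the compounds shown here, the exchange of bromo for methyl, on an aromatic carbon para to a large group, gives a 1.1-fold lower number from compound 1 to compound 3 (0.05 log units; within the scatter) and is the only one-place comparison available. At this position, 4-bromophenyl and 4-methylphenyl therefore cannot be told apart in this read-out, so this single pair shows that the exchange of these two groups leaves the reading within the scatter. No measurement at hand bears on the reason for this.

Still open, on these data alone, is whether an amine, a carboxylic acid or a longer alkyl chain at this position would give a step beyond the scatter. Also open, as far as these compounds go, is whether the same exchange of bromo for methyl would read alike on the core of compound 2.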